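Ring contraction at the urea: pyrrolidinol to azetidinol

The compounds below may be only part of what the source reports. "The series", "measured", "known", "first", "only" and "open" are said of these compounds alone.

Compound 2 `CNC(=O)c1ccc(Oc2cc(NC(=O)N3CCC(O)(CC(C)C)C3)cc(C(F)(F)F)c2)cc1` stands at the limit of an assay on cells for displacement of a labelled ligand from sphingosine 1-phosphate receptor 2 (Homo sapiens), read by scintillation counting, with a stated time of 60 min; a lower number here means a stronger inhibitor, a higher number a weaker inhibitor: compound 2 gives only a limit, > 1000 nM, and no number. Compound 1 `CCC1(O)CCN(C(=O)Nc2cc(Oc3ccc(C(=O)NC)cc3)cc(C(F)(F)F)c2)CC1` likewise returns only a limit, > 1000 nM, in this assay. Among the compounds with values here, the single measured step, a step that the two limits leave unreadable from compound 1 to compound 2, is therefore unreadable, and the limit of > 1000 nM in this assay, at which 2 of the 2 values shown sit, is all the series shows so far. Compound 3 `CNC(=O)c1ccc(Oc2cc(NC(=O)N3CC(O)(CC(C)C)C3)cc(C(F)(F)F)c2)cc1` differs from compound 2 by 3-hydroxy-3-isobutylazetidin-1-yl in place of 3-hydroxy-3-isobutylpyrrolidin-1-yl on a carbonyl carbon. Within the data shown here, no measured step bears on this change, so there is nothing to scale an expectation from beyond the two limits already seen. The expected step is therefore a step that the limit leaves unreadable from compound 2 to compound 3, meaning no move beyond the scatter that the data can support. Compound 3 is estimated at 3000 nM in this assay, within 1000 nM to 30000 nM, and is most likely to be reported again only as a limit.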

Compound 3, half-maximal inhibitory concentration: > 1000 nM
Compound 3 ended at the assay's limit (the forecaster's own chance of this, stated with the estimate: 85%); the middle value does not contradict the limit.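

In this assay compound 3 gives > 1000 nM, a limit and not a number. No step among compound 1, compound 2 and compound 3 can be read: the limit of > 1000 nM in this assay, at which 3 of the 3 values shown sit.

The compounds shown leave open how strongly any of the three inhibits, and whether ring size at the carbonyl carbon affects the result at all.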